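A few compounds are considered here, and "the series" means these few. Any claim that something is new, unique, unknown or untested is made for them only; others in the source may bear on it.

Compound 1 `COc1cc(OC)cc(-c2cccc(NC(=O)CCc3ccc4c(c3)B(O)OC4)c2)c1` and compound 2 `CC(=O)c1ccc(-c2cccc(NC(=O)CCc3ccc4c(c3)B(O)OC4)c2)cc1` share one core, while compound 3 `COc1cc(OC)cc(-c2cccc(NC(=O)CCc3cccc4c3COB4O)c2)c1` and compound 4 `CC(=O)c1ccc(-c2cccc(NC(=O)CCc3cccc4c3COB4O)c2)cc1` carry another. The two cores differ as a group of 10 heavy atoms (7 carbon, 1 boron, 2 oxygen; one five-membered non-aromatic ring with 2 hetero atoms, one six-membered aromatic ring of carbon only) in place of a group of 10 heavy atoms (7 carbon, 1 boron, 2 oxygen; one five-membered non-aromatic ring with 2 hetero atoms, one six-membered aromatic ring of carbon only), on a saturated chain carbon, two bonds along the chain from a carbonyl carbon. In an ADME assay on WI-38 cells (Homo sapiens) for cytotoxicity, read by MTT assay, with a stated time of 72 h (on this read-out higher numbers stand for weaker inhibition and lower numbers for stronger inhibition), compound 1 reaches only the assay limit, > 100000 nM. Compound 2 likewise gives only a limit in this assay, > 100000 nM. Compound 3 also stops at a limit in this assay, > 100000 nM. The change from compound 1 to compound 2 is 4-acetylphenyl in place of 3,5-dimethoxyphenyl on an aromatic carbon, and its step is a step that the two limits leave unreadable from compound 1 to compound 2. The core swap gives a step that the two limits leave unreadable from compound 1 to compound 3. The same change, (4-acetylphenyl in place of 3,5-dimethoxyphenyl on an aromatic carbon), leads to compound 4. Compound 4 is expected to rest at that limit too, a step of a number no higher from compound 3 to compound 4 (the limit leaves the size open), because the limit of > 100000 nM in this assay, at which 3 of the 3 values shown sit, shows every value sitting there. The estimate for compound 4 is 100000 nM, spanning 50000 nM to 300000 nM.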

Compound 4, half-maximal inhibitory concentration: > 100000 nM
Compound 4 ended at the assay's limit; the forecaster's own chance of this, stated with the estimate: 90%; the middle value sits exactly at the limit.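

Compound 2, compound 3 and compound 4 all stop at a limit in this assay, so neither step to compound 4 can be read. The compounds shown leave open whether either change affects cytotoxicity at all.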